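Working notes on compound 3 of the series

A few compounds are considered here, and "the series" means these few. Any claim that something is new, unique, unknown or untested is made for them only; others in the source may bear on it.

Among the compounds with values here, compound 2 `COc1cc(C(=O)c2sc(-c3cccc([N+](=O)[O-])c3)cc2N)cc(OC)c1OC` stands at the lower of the two numbers so far: in a functional assay on CCRF-CEM cells (Homo sapiens) for antiproliferative activity (on this read-out lower numbers stand for stronger inhibition and higher numbers for weaker inhibition), compound 2 gives 5.9 nM, whereas compound 1 `COc1ccc(-c2cc(N)c(C(=O)c3cc(OC)c(OC)c(OC)c3)s2)cc1OC` gives 20 nM. Within the data shown here, the one measured step, a 3.4-fold lower number from compound 1 to compound 2 (0.53 log units; beyond the scatter), concerns a different replacement on the same aromatic carbon. Compound 3 `COc1cc(C(=O)c2sc(-c3ccc(Cl)c(Cl)c3)cc2N)cc(OC)c1OC` carries 3,4-dichlorophenyl in place of 3-nitrophenyl on an aromatic carbon. Among the measured compounds shown here, no measured step covers this change, so no shift beyond the scatter is expected in either direction. Compound 3 is expected to give about 8 nM, within 3 nM to 25 nM. That amounts to an expected step of a 1.4-fold higher number from compound 2 to compound 3 (0.13 log units; within the scatter).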

Compound 3, half-maximal inhibitory concentration: 290 nM
Estimate against measurement, compound 3: 36-fold (1.56 log units) below; the measured number lies above the stated range.
By their numbers in this assay, from the lowest: compound 2; then compound 1; then compound 3.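

This position does not tolerate every aryl group alike: 3,4-dichlorophenyl in place of 3-nitrophenyl gives a 49-fold higher number from compound 2 to compound 3 (1.69 log units; beyond the scatter). That change outweighs the earlier step between compound 1 and compound 2. In place of 3,4-dimethoxyphenyl, the same group gives a 15-fold higher number from compound 1 to compound 3 (1.16 log units; beyond the scatter) and so places compound 3 highest of the three, with both steps beyond the scatter. No supporting data bear on the reason for this loss.
The compounds shown leave open whether a single chlorine on the phenyl ring would give the same loss as the pair. They also leave open where a 3-aminophenyl group would stand.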